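A few compounds are considered here, and "the series" means these few. Any claim that something is new, unique, unknown or untested is made for them only; others in the source may bear on it.

In a functional assay on the whole organism (aorta) with Rattus norvegicus as the target (on this read-out higher numbers stand for larger maximal responses and lower numbers for smaller maximal responses), three close relatives of one core have been measured. Compound 1, `C/N=C(/S)C1=CC(CF)(CF)Oc2ccc([N+](=O)[O-])cc21`, gives 74.5%; compound 2, `C/N=C(/S)C1=CC(C)(C(F)(F)F)Oc2ccc([N+](=O)[O-])cc21`, gives 62.5%; and compound 3, `C/N=C(/S)C1=CC(C(F)(F)F)(C(F)(F)F)Oc2ccc([N+](=O)[O-])cc21`, gives 68%. All three sit within the usual scatter of one another, so compound 3 stands among them without a separation that could be read as a difference. Going by the values given here, the only single-point step among them, a number 5.5 percentage points higher from compound 2 to compound 3 (within the scatter), is itself within the scatter.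

The next member is compound 4, `CNC(=O)C1=CC(C(F)(F)F)(C(F)(F)F)Oc2ccc([N+](=O)[O-])cc21`. It keeps the core of compound 3 with both trifluoromethyl groups and changes the substituent on the double-bonded ring carbon: a group of 4 heavy atoms (2 carbon, 1 nitrogen, 1 oxygen; no ring) in place of a group of 4 heavy atoms (2 carbon, 1 nitrogen, 1 sulfur; no ring), on a double-bonded ring carbon. Among the compounds with values here, no measured pair shows this exchange; the one step recorded, from compound 2 to compound 3, concerns a saturated ring carbon and says nothing about what a change at this position does. Since the measured compounds all fall within a narrow band, compound 4 is expected to remain near that band, with the uncertainty of an untested change widening the range.

Compound 4 is expected to reach 64%, between 45% and 80%, in this assay. That estimate means a step of a number 4 percentage points lower from compound 3 to compound 4 (within the scatter), which is expected to stay within the scatter.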

Compound 4, intrinsic activity: the largest response reached, in percent of the reference agonist's: 57.9%
Compound 4: the middle estimate sits 6.1 percentage points above what was measured; low and high end bracket the measured number.
By their numbers in this assay, from the lowest: compounds 4, 2, 3 and 1 (each within the scatter of the next, the first and the last beyond it).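

In this assay, going by these compounds alone, putting methylcarbamoyl in place of the sulfur-bearing group on the double-bonded ring carbon gives a number 10.1 percentage points lower from compound 3 to compound 4 (beyond the scatter), and it is the only step between compounds differing in one place here that lies beyond the scatter. This shows that the position is not indifferent to the exchange: the two groups match in every count computed, differing only in that oxygen takes the place of sulfur, yet the maximal response still shifts, although the step is modest. The compounds shown offer no measurement that accounts for this shift.

Open, on these data alone, is whether the exchange would have the same size with other substituents on the saturated ring carbon, since it is seen here only with the two trifluoromethyl groups of compound 3 and compound 4, and not with the methyl and trifluoromethyl pair of compound 2 or the substituents of compound 1. Also open, as far as these compounds go, is how other groups on the double-bonded ring carbon would behave, such as a nitrile, a carboxylic acid or an amide with a longer chain on its nitrogen.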